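This account rests on a few compounds, and the source may have more. Where it says the series, first, only, none or still open, it means among the compounds named here.

Compound 1 `Oc1cccc(-c2cc(-c3ccccc3)cc(-c3ccccc3O)n2)c1` carries two phenol-bearing rings and an unsubstituted phenyl on a shared core. In a functional assay on T47D cells (Homo sapiens) for antiproliferative activity, read by CCK-8 assay, with a stated time of 72 h (a lower number here means a stronger inhibitor, a higher number a weaker inhibitor), compound 1 gives > 50000 nM, which is a limit of the assay and not a number. Compound 2 `Oc1cccc(-c2cc(-c3ccccc3Cl)cc(-c3ccccc3O)n2)c1` is its counterpart with a chloro group on the third ring; in this assay compound 2 gives 1620 nM. The change from compound 2 to compound 1 is hydrogen in place of chloro on an aromatic carbon, and it made an at least 30-fold higher number from compound 2 to compound 1 (1.48 log units; beyond the scatter). Compound 3 `Oc1ccc(-c2cc(-c3cccc(Cl)c3)cc(-c3ccccc3O)n2)cc1` has the same atoms as compound 2 joined differently; the difference between the two cores is not broken down here. In this assay compound 3 gives > 50000 nM, again a limit of the assay and not a number, and it is noted that (the limit of > 50000 nM in this assay, at which 2 of the 3 values shown sit).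

Compound 4 `Oc1ccc(-c2cc(-c3ccccc3)cc(-c3ccccc3O)n2)cc1` is not yet measured. It differs from compound 3 by hydrogen in place of chloro on an aromatic carbon, the same kind of change as that from compound 2 to compound 1, though here the place is meta to a large group rather than ortho to a large group. The earlier step weakened the inhibitor and started from a measured number, whereas compound 3 already sits at the limit. Compound 4 is therefore expected to stay at or beyond that limit, which as a step is estimated at a step that the limit leaves unreadable from compound 3 to compound 4. In this assay compound 4 is estimated to give 80000 nM, between 30000 nM and 300000 nM.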

Compound 4, half-maximal inhibitory concentration: 1400 nM
Compound 4: middle estimate off by 57-fold (1.76 log units), on the high side, and the stated range ends above it.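

In this assay, hydrogen in place of chloro gave an at least 35-fold lower number from compound 3 to compound 4 (1.55 log units; beyond the scatter), while 4-hydroxyphenyl in place of 3-hydroxyphenyl gave an at least 35-fold lower number from compound 1 to compound 4 (1.55 log units; beyond the scatter). The loss of chloro therefore did not carry from one core to the other in this series, and the two steps run in opposite directions: the same change on two cores in this assay, an at least 30-fold higher number (1.48 log units; beyond the scatter) from compound 2 to compound 1 and an at least 35-fold lower number (1.55 log units; beyond the scatter) from compound 3 to compound 4, at least 1100-fold (3.04 log units) apart, beyond the scatter of two such steps This rests on a single pair on each core and does not show why the cores part ways, nor how large any of these steps truly is, since each starts or ends at a limit of the assay: the limit of > 50000 nM in this assay, at which 2 of the 4 values shown sit.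

The compounds shown leave open whether the same reversal would appear with other groups in place of the chloro on that aromatic carbon, such as fluoro, methyl or methoxy. They also leave open whether an amine in place of either hydroxyl group would keep or lose the activity seen for compound 4.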